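The source may report more compounds than this note shows. Statements on the series, on what has been measured and on what is new or still open speak of the compounds shown alone.

Measured so far:
compound 1 `O=C(/C(=C\c1ccc(F)c([N+](=O)[O-])c1)S(=O)(=O)c1ccc(Br)cc1)c1ccc(Br)cc1` — 25000 nM
compound 2 `COc1ccc(/C=C(/Sc2ccc(C)cc2)C(=O)c2ccc(Br)cc2)cc1` — 50000 nM
compound 3 `Cc1ccsc1/C=C(/SCc1ccc(Cl)cc1Cl)C(=O)c1ccc(Cl)cc1` — 10000 nM

All three numbers come from a functional assay on DU-145 cells (Homo sapiens) for inhibition, read by trypan blue exclusion, with a stated time of 96 h; on this read-out lower numbers stand for stronger inhibition of growth and higher numbers for weaker inhibition of growth. Compound 1 stands second highest of the three. Its nearest neighbour is compound 2, whose number is within the usual scatter of that of compound 1, so nothing can be said about an order between these two. Compound 3 lies furthest from compound 1, beyond the scatter, with the lower number; on this read-out that means stronger inhibition of growth for compound 3 than for compound 1.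

Compound 4 `O=C(/C(=C\c1c[nH]c2ccccc12)S(=O)(=O)c1ccc(Br)cc1)c1ccc(Br)cc1` has not yet been measured in this assay. It differs from compound 1 in one place: 1H-indol-3-yl in place of 4-fluoro-3-nitrophenyl on a double-bonded chain carbon bound to a double-bonded chain carbon. The group that leaves is 4-fluoro-3-nitrophenyl, the group that enters is 1H-indol-3-yl; the rest of the shared core of compound 1 is kept.

Among the compounds with values here, no measured pair in the set shows a change of this kind, so there is nothing to calibrate the step against. All three numbers sit in a narrow, weak band, and the step from compound 1 to compound 4 is expected to be modest, if anything towards a lower number, possibly not beyond the scatter: a 2.1-fold lower number from compound 1 to compound 4 (0.32 log units; beyond the scatter). Compound 4 is therefore estimated at 12000 nM in this assay, with a range from 3000 nM to 50000 nM.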

Compound 4, concentration for 50% growth inhibition: 25000 nM
Compound 4: the middle estimate sits 2.1-fold (0.32 log units) below what was measured; low and high end bracket the measured number.
By their numbers in this assay, from the lowest: compound 3; then compounds 1, 4 and 2 (each within the scatter of the next).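

Replacing 4-fluoro-3-nitrophenyl with 1H-indol-3-yl on a double-bonded chain carbon bound to a double-bonded chain carbon gives, in this assay, no change at the digits printed from compound 1 to compound 4 (within the scatter). Within the data shown here, this is the first readable single-place step. At this position, a group with a five-membered and a six-membered aromatic ring and a hydrogen-bond donor takes the place of a single six-membered aromatic ring with hydrogen-bond acceptors, and the number stays within the scatter. No independent data bear on this result.

Among these compounds, with only one step at this position, it remains open whether any group there can move the number beyond the scatter. A phenyl ring carrying a carboxylic acid or an amine at the same place would test this.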